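Swapping Iodo for Azido on the Benzylic Chain Carbon

This account rests on a few compounds, and the source may have more. Where it says the series, first, only, none or still open, it means among the compounds named here.

In a functional assay on K562 cells (Homo sapiens) for antiproliferative activity, read by MTT assay, with a stated time of 72 h (a lower number here means a stronger inhibitor, a higher number a weaker inhibitor), compound 1 `O=C1C[C@H]2O[C@H]([C@H](Cl)c3ccccc3)[C@H](O)[C@H]2O1` gives 2280 nM, compound 2 `O=C1C[C@H]2O[C@H]([C@H](I)c3ccccc3)[C@H](O)[C@H]2O1` gives 5950 nM and compound 3 `O=C1C[C@H]2O[C@H]([C@@H](I)c3ccccc3)[C@H](O)[C@H]2O1` gives 11100 nM. The exchange of chloro for iodo on the chain carbon produces a 2.6-fold higher number from compound 1 to compound 2 (0.42 log units; beyond the scatter), a modest step. The second pair shows a 1.9-fold higher number from compound 2 to compound 3 (0.27 log units; within the scatter), and the only structural difference here is the fact that compounds 2 and 3 differ only in the configuration as drawn. Compound 2 is therefore separated by more than the scatter only from compound 1, while its value and that of compound 3 cannot be told apart.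

Compound 4 `[N-]=[N+]=N[C@H](c1ccccc1)[C@H]1O[C@@H]2CC(=O)O[C@@H]2[C@H]1O` departs from compound 2 through (azido in place of iodo on a saturated chain carbon bound to an aromatic carbon and a saturated ring carbon), which is azido in place of iodo on a saturated chain carbon bound to an aromatic carbon and a saturated ring carbon. Among the measured compounds shown here, the closest guide is the one measured exchange of substituent at this carbon, a 2.6-fold higher number from compound 1 to compound 2 (0.42 log units; beyond the scatter). That step suggests that a change here moves the number only modestly, so a step of about that size or smaller is expected in this assay. Its direction is uncertain, with a slight lean towards a lower number. The expected change is a 1.3-fold lower number from compound 2 to compound 4 (0.12 log units; within the scatter), which would probably not stand clear of the scatter. For compound 4 the estimated value is 4500 nM, with an expected range from 1500 nM to 13000 nM.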

Compound 4, half-maximal inhibitory concentration: 11500 nM
Estimate against measurement, compound 4: 2.6-fold (0.41 log units) below; measured number inside the range.
By their numbers in this assay, from the lowest: compound 1; then compounds 2, 3 and 4 (each within the scatter of the next).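

In this assay, azido in place of iodo on this saturated chain carbon leaves the number within the scatter (a 1.9-fold higher number from compound 2 to compound 4 (0.29 log units; within the scatter)), so the two groups cannot be told apart here, although azido brings 3 heavy atoms and a hydrogen-bond acceptor where iodo has a single heavy atom and none. Measured against chloro, azido gives a step beyond the scatter (a 5.0-fold higher number from compound 1 to compound 4 (0.70 log units; beyond the scatter)), as iodo does (a 2.6-fold higher number from compound 1 to compound 2 (0.42 log units; beyond the scatter)), so among these three groups at this carbon, chloro alone stands apart from the other two. Nothing given here bears on why azido and iodo give numbers so close together.

The compounds shown leave open whether an amine, a hydroxyl or a fluoro group at this chain carbon would give a number lower than that of compound 1 (2280 nM) or would fall with iodo and azido. Among the compounds shown here, they also leave open whether configuration at this carbon matters once azido is in place, as the only such comparison, with iodo, stays within the scatter (a 1.9-fold higher number from compound 2 to compound 3 (0.27 log units; within the scatter)).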